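Adding a methoxy group to the phenyl of compound 3

A few compounds are considered here, and "the series" means these few. Any claim that something is new, unique, unknown or untested is made for them only; others in the source may bear on it.

- compound 1 `CCCCCCOc1ccc(-n2cnnc2CC)cc1` gives in a functional assay on the whole organism (strain C57B/6) with Mus musculus as the target, in the maximal electroshock model (on this read-out lower numbers stand for an effect already at smaller amounts and higher numbers for an effect only at larger amounts of compound), 13.2 mg/kg.
- compound 2 `CCCCCCCc1nncn1-c1ccc(OCCCCCC)cc1` reaches in this assay only a limit, > 40 mg/kg.
- compound 3 `CCCCCCOc1ccc(-n2cnnc2-c2ccccc2)cc1` gives in this assay 19 mg/kg.

Compound 3 holds the highest of the two numbers; its nearest neighbour is compound 1, with a 1.4-fold higher number from compound 1 to compound 3 (0.16 log units; within the scatter), and the remaining value is a limit (the limit of > 40 mg/kg in this assay, at which 1 of the 3 values shown sits). Compound 4 `CCCCCCOc1ccc(-n2cnnc2-c2ccc(OC)cc2)cc1` differs from compound 3 by methoxy in place of hydrogen on an aromatic carbon. For the measured compounds named here, no measured step alters this phenyl itself. The steps that touch the same aromatic carbon of the shared core are a 1.4-fold higher number from compound 1 to compound 3 (0.16 log units; within the scatter) and an at least 2.1-fold lower number from compound 2 to compound 3 (0.32 log units; beyond the scatter). Neither tells how a methoxy on the phenyl behaves, and the expected step in this assay is then one within the scatter, a 1.1-fold higher number from compound 3 to compound 4 (0.02 log units; within the scatter). Compound 4 is estimated at 20 mg/kg, with a range from 8 mg/kg to 45 mg/kg.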

Compound 4, dose for half-maximal effect: 15.8 mg/kg
For compound 4 the middle estimate is 1.3-fold (0.10 log units) above the measured one; low and high end bracket the measured number.
By their numbers in this assay, from the lowest: compounds 1, 4 and 3 (each within the scatter of the next). At a limit, above all of these: compound 2.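

In this assay the phenyl of compound 3 takes a methoxy para to a large group with no step beyond the scatter, at a 1.2-fold lower number from compound 3 to compound 4 (0.08 log units; within the scatter). The 4-methoxyphenyl in place of ethyl likewise stays within the scatter, at a 1.2-fold higher number from compound 1 to compound 4 (0.08 log units; within the scatter), while in place of heptyl it gives an at least 2.5-fold lower number from compound 2 to compound 4 (0.40 log units; beyond the scatter). That last step is only a bound, as compound 2 stands at a limit: the limit of > 40 mg/kg in this assay, at which 1 of the 4 values shown sits.

From the compounds shown here alone, what an amine or a carboxylic acid would do on this phenyl stays open. So does a butyl chain in place of the ethyl of compound 1.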